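Adding 6-(nitrooxy)hexyl to the aromatic oxygen of compound 1

The compounds below may be only part of what the source reports. "The series", "measured", "known", "first", "only" and "open" are said of these compounds alone.

Compound 1 `COc1cc(/C=C/C(=O)OCCCCCCO[N+](=O)[O-])ccc1O`: > 50000 nM (a limit, not a number)
Compound 2 `COc1cc(/C=C/C(=O)OCCCCCO[N+](=O)[O-])ccc1O`: 20800 nM
Compound 3 `COc1cc(/C=C/C(=O)OCCCO[N+](=O)[O-])ccc1O`: 28300 nM

All three were tested in a functional assay on NCI-H1299 cells (Homo sapiens) for cytotoxicity, read by resazurin assay, with a stated time of 72 h; on this read-out lower numbers stand for stronger inhibition and higher numbers for weaker inhibition. Compound 1 reads > 50000 nM, and this is a limit of the assay, not a number. It is the only such result here: the limit of > 50000 nM in this assay, at which 1 of the 3 values shown sits.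

Compound 4 `COc1cc(/C=C/C(=O)OCCCCCCO[N+](=O)[O-])ccc1OCCCCCCO[N+](=O)[O-]` keeps the core of compound 1 and changes in one place: 6-(nitrooxy)hexyl in place of hydrogen on an oxygen on an aromatic ring.

Going by the values given here, no measured step touches that oxygen. The nearest evidence comes from changes in chain length: an at least 2.4-fold lower number from compound 1 to compound 2 (0.38 log units; beyond the scatter), an at least 1.7-fold lower number from compound 1 to compound 3 (0.24 log units; that floor lies within the scatter) and a 1.4-fold higher number from compound 2 to compound 3 (0.13 log units; within the scatter). These give only indirect guidance, so no step beyond the scatter is expected in this assay, and another limit is quite possible. The expected change is an at least 1.4-fold lower number from compound 1 to compound 4 (0.15 log units; that floor lies within the scatter).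

The estimated value for compound 4 is 35000 nM, with an expected range of 12000 nM to 70000 nM.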

Compound 4, half-maximal inhibitory concentration: > 50000 nM
Compound 4 ended at the assay's limit (the forecaster's own chance of this, stated with the estimate: 45%); at least 1.4-fold (0.15 log units) between middle value and limit.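

Compound 1 and compound 4 both end at a limit of the assay rather than at a number, so the step between them cannot be read: the limit of > 50000 nM in this assay, at which 2 of the 4 values shown sit.

The compounds shown leave open whether 6-(nitrooxy)hexyl in place of hydrogen on an oxygen on an aromatic ring changes the result in this assay at all.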